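Methoxy additions in a small cytotoxicity series

This account rests on a few compounds, and the source may have more. Where it says the series, first, only, none or still open, it means among the compounds named here.

Measured so far:
compound 1 `O=C1OC[C@H](Cc2ccccc2)[C@H]1Cc1ccccc1`: 77000 nM
compound 2 `COc1ccccc1C[C@H]1C(=O)OC[C@@H]1Cc1ccccc1`: 79000 nM
compound 3 `COc1ccc(C[C@H]2C(=O)OC[C@@H]2Cc2ccccc2)cc1OC`: only a limit, > 100000 nM

In a functional assay on HL-60 cells (Homo sapiens) for cytotoxicity, read by WST assay, with a stated time of 48 h (on this read-out higher numbers stand for an effect only at larger amounts of compound and lower numbers for an effect already at smaller amounts), compound 1 gives 77000 nM and compound 2 gives 79000 nM. For compound 3 this assay reports a limit, > 100000 nM (the limit of > 100000 nM in this assay, at which 1 of the 3 values shown sits). The change methoxy in place of hydrogen on an aromatic carbon gives a 1.0-fold higher number from compound 1 to compound 2 (0.01 log units; within the scatter). Compound 4 `COc1cc(C[C@H]2C(=O)OC[C@@H]2Cc2ccccc2)cc(OC)c1OC` carries the same kind of change on the core of compound 3: methoxy in place of hydrogen on an aromatic carbon. Around the place the surroundings differ: in compound 2 the new group sits ortho to a large group, in compound 4 ortho to a methoxy group, meta to a large group and meta to a methoxy group. The difference between the two cores is not broken down here. For compound 4 the expected step is a step that the limit leaves unreadable from compound 3 to compound 4, because a 1.0-fold higher number from compound 1 to compound 2 (0.01 log units; within the scatter) lies within the scatter and compound 3 already sits at a limit > 100000 nM. Compound 4 is estimated at 150000 nM, range 80000 nM to 400000 nM, most likely again reported as a limit.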

Compound 4, half-maximal effective concentration: > 100000 nM
Compound 4: only a limit was reported; the forecaster's own chance of this, stated with the estimate: 80%; the middle value is on the limit's open side.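

No step from compound 3 to compound 4 can be read, as both values are only limits: the limit of > 100000 nM in this assay, at which 2 of the 4 values shown sit.

The compounds shown leave open whether the added methoxy changes the read-out for compound 4 relative to compound 3, and in which direction.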